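The source may report more compounds than this note shows. Statements on the series, on what has been measured and on what is new or still open speak of the compounds shown alone.

In a functional assay on CHO-K1 cells (Cricetulus griseus) for inhibition, read by sulforhodamine B assay, with a stated time of 72 h (on this read-out lower numbers stand for stronger inhibition and higher numbers for weaker inhibition), compound 1 `CCC(C)NC(=C\C(=O)/C=C/c1ccc(O)c(OC)c1)/C=C/c1ccc(O)c(OC)c1` gives > 25000 nM, which is a limit and not a number, and so it stands at the limit of > 25000 nM in this assay, at which 2 of the 3 values shown sit. Compound 3 `COc1cc(/C=C/C(=O)CC(=O)/C=C/c2ccc(OC(C)=O)c(OC)c2)ccc1OC(C)=O` gives > 25000 nM, also a limit. Compound 2 `CC(C)CNC(=C\C(=O)/C=C/c1ccc(O)cc1)/C=C/c1ccc(O)cc1` alone gives a number, 23700 nM. Compound 4 `CCCCNC(=C\C(=O)/C=C/c1ccc(O)c(OC)c1)/C=C/c1ccc(O)c(OC)c1` differs from compound 1 in one place: butyl in place of sec-butyl on an amine nitrogen, with butyl in place of sec-butyl on an amine nitrogen. Going by the values given here, no measured pair shows what such a change does, so no step beyond the scatter is expected in this assay, and inhibition should remain weak. The expected step is an at least 1.0-fold lower number from compound 1 to compound 4 (0.01 log units; that floor lies within the scatter). Compound 4 is estimated at 24000 nM, with an expected range of 12000 nM to 40000 nM.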

Compound 4, half-maximal inhibitory concentration: 20400 nM
For compound 4 the middle estimate is 1.2-fold (0.07 log units) above the measured one; the measured number falls inside the stated range.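

In this assay, the amine nitrogen now has its first comparison that differs in one place: butyl in place of sec-butyl gives an at least 1.2-fold lower number from compound 1 to compound 4 (0.08 log units; that floor lies within the scatter). This step is only a floor, because compound 1 stands at a limit and not at a number: the limit of > 25000 nM in this assay, at which 2 of the 4 values shown sit.

The compounds shown leave open how far compound 1 really lies from compound 4. They also leave open whether a shorter chain such as ethyl, a longer chain such as octyl, or a benzyl group on this nitrogen would move the number beyond the scatter in this assay.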